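Swapping Tert-Butyl for Bromo: What to Expect

This account rests on a few compounds, and the source may have more. Where it says the series, first, only, none or still open, it means among the compounds named here.

Of the compounds shown here, three have been measured in an ADME assay on the whole organism with Oryza sativa as the target, tested at 0.1 uM; a lower number here means a stronger effect, a higher number a weaker effect of the compound at the concentration tested. Compound 1, `C[C@@H](NC(=O)Nc1ccccc1C(C)(C)C)c1ccccc1`, gives 100%. Compound 2, `C[C@H](NC(=O)Nc1ccccc1C(C)(C)C)c1ccccc1`, gives 101%. Compound 3, `C[C@H](NC(=O)Nc1ccc(F)cc1)c1ccccc1`, gives 96%. For the measured compounds named here, the only followed change between measured compounds is a number 1 percentage points higher from compound 1 to compound 2 (within the scatter), a change that rests on the fact that compounds 1 and 2 differ only in the configuration as drawn and touched no substituent. The numbers of compound 2 and compound 3 also lie within the usual scatter of each other, so compound 2 cannot be set apart from either neighbour; all three numbers sit close to complete activity.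

Compound 4, `C[C@H](NC(=O)Nc1ccccc1Br)c1ccccc1`, is the next compound to be measured. Relative to compound 2 the structural change is bromo in place of tert-butyl on an aromatic carbon. Going by the values given here, no measured step swaps one group for another on a ring, so the change from compound 1 to compound 2 gives no direct guide to a substituent swap; the only lead is that every measured number, with or without a ring substituent, stays near complete activity. The step is therefore expected to be small, a number 3 percentage points lower from compound 2 to compound 4 (within the scatter), with no direction beyond the scatter. For compound 4 in this assay the estimate is 98%, expected to fall between 85% and 108%.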

Compound 4, a percentage reported as activity, at one concentration (the size of the read-out at that concentration, not a potency): 101%
Compound 4: middle estimate off by 3 percentage points, on the low side; low and high end bracket the measured number.
By their numbers in this assay, from the lowest: compounds 3, 1, 2 and 4 (each within the scatter of the next).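

For the compounds shown here, this is the first measured swap of one group for another on this ring, and in this assay it gives no change at the digits printed from compound 2 to compound 4 (within the scatter) when bromo replaces tert-butyl on an aromatic carbon, ortho to a large group. Going from a group of 4 heavy atoms to a single bromine atom, both with no hydrogen-bond donors or acceptors and no net charge, therefore leaves the read-out of this pair indistinguishable at the concentration tested. The one available piece of background concerns only a difference in drawn configuration and offers no explanation for this substituent swap.

Still open, as far as these compounds go, is whether a group of a different kind at this aromatic carbon, such as an amine, a carboxylic acid or a nitrile, would shift the number beyond the usual scatter. The compounds shown also leave open whether the drawn configuration matters once bromo is in place, and whether the two groups would still match at other concentrations, as a single-concentration read-out is not a potency.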